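The source may report more compounds than this note shows. Statements on the series, on what has been measured and on what is new or still open speak of the compounds shown alone.

Compound 2 `COc1cccc(Cn2nnc(-c3ccccc3)c2C(=O)N[C@@H](C)c2ccc(C(=O)O)cc2)c1` gives the highest of the two numbers in a functional assay on CHO cells for antagonist activity at prostaglandin E2 receptor EP4 subtype (Homo sapiens), read by calcium flux, with a stated time of 15 min (on this read-out lower numbers stand for stronger inhibition and higher numbers for weaker inhibition), namely 96.8 nM, while compound 1 `COc1ccc(Cn2nnc(-c3ccccc3)c2C(=O)N[C@@H](C)c2ccc(C(=O)O)cc2)cc1` gives 9.3 nM. Among the compounds with values here, the one measured step, a 10-fold higher number from compound 1 to compound 2 (1.02 log units; beyond the scatter), shows that moving the methoxy group alone shifts the number a great deal. Compound 3 `C[C@H](NC(=O)c1c(-c2ccccc2)nnn1CCOc1ccc(C(F)(F)F)cc1)c1ccc(C(=O)O)cc1` differs from compound 2 in another way: (4-(trifluoromethyl)phenoxy)methyl in place of 3-methoxyphenyl on a saturated chain carbon bound to an aromatic nitrogen. Within the data shown here, no measured step covers this replacement, so the expectation rests loosely on the shift seen in a 10-fold higher number from compound 1 to compound 2 (1.02 log units; beyond the scatter). Compound 3 is therefore expected at 30 nM, between 3 nM and 300 nM, a step of a 3.2-fold lower number from compound 2 to compound 3 (0.51 log units; beyond the scatter) toward a lower number.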

Compound 3, half-maximal inhibitory concentration: 49.1 nM
Beside the measured number, compound 3's estimate is 1.6-fold (0.21 log units) below it; the measured number falls inside the stated range.
By their numbers in this assay, from the lowest: compound 1; then compounds 3 and 2 (each within the scatter of the next).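

At this position, on a saturated chain carbon bound to an aromatic nitrogen, (4-(trifluoromethyl)phenoxy)methyl, with 12 heavy atoms, replaces 3-methoxyphenyl, with 8, and the number stays level (a 2.0-fold lower number from compound 2 to compound 3 (0.29 log units; within the scatter)). The same group in place of 4-methoxyphenyl does not match compound 1 (a 5.3-fold higher number from compound 1 to compound 3 (0.72 log units; beyond the scatter)). No measurement here explains either result. Open, on these data alone, is how an amine or a carboxylic acid in place of the trifluoromethyl would read, and whether moving the trifluoromethyl around its ring matters as much as moving the methoxy did.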